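Benzyl for methyl on the amide nitrogen of compound 2

The source may hold more compounds than are shown below. What is called first, only, known or untested is meant among the compounds shown, and "the series" means these compounds.

Compound 2 `CN1C(=O)C2(C(C#N)=C(N)Oc3cc4oc(-c5ccccc5)cc(=O)c4c(O)c32)c2cccc(Cl)c21` shows only a limit in a functional assay on NCI-H1299 cells (Homo sapiens) for antiproliferative activity, read by MTT assay, with a stated time of 48 h (a lower number here means a stronger inhibitor, a higher number a weaker inhibitor), namely > 50000 nM. Compound 1 `CN1C(=O)C2(C(C#N)=C(N)Oc3cc4oc(-c5ccccc5)cc(=O)c4c(O)c32)c2ccccc21` is likewise reported as a limit, > 50000 nM. Compound 3 `CN1C(=O)C2(C(C#N)=C(N)Oc3cc4oc(-c5ccccc5)cc(=O)c4c(O)c32)c2cc(Cl)ccc21` gives a number, 11200 nM. Among the compounds with values here, the step that the two limits leave unreadable from compound 1 to compound 2 cannot be read, while an at least 4.4-fold lower number from compound 1 to compound 3 (0.64 log units; beyond the scatter) is at least modest; both concern chloro in place of hydrogen on an aromatic carbon and therefore the limit of > 50000 nM in this assay, at which 2 of the 3 values shown sit, is the only evidence on where compound 2 stands. Compound 4 `N#CC1=C(N)Oc2cc3oc(-c4ccccc4)cc(=O)c3c(O)c2C12C(=O)N(Cc1ccccc1)c1c(Cl)cccc12` differs from compound 2 by phenyl in place of hydrogen on a saturated chain carbon bound to an amide-type nitrogen in a ring. Within the data shown here, no measured step touches that place, so no shift beyond the scatter is expected, and compound 4 is estimated at 45000 nM (range 10000 nM to 200000 nM), a step of an at least 1.1-fold lower number from compound 2 to compound 4 (0.04 log units; that floor lies within the scatter) that is only a guess.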

Compound 4, half-maximal inhibitory concentration: > 50000 nM
Compound 4 gave a limit, no number; the forecaster's own chance of this, stated with the estimate: 60%; middle value at least 1.1-fold (0.04 log units) away from the limit.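

Within the data shown here, compound 4 is reported only as a limit in this assay, > 50000 nM; compound 2 is also a limit, so no step between compound 2 and compound 4 can be read. On these data alone, whether methyl to benzyl changes the read-out at all stays open.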